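Adding a hydroxy to the phenyl of compound 3

This account rests on a few compounds, and the source may have more. Where it says the series, first, only, none or still open, it means among the compounds named here.

In an ADME assay on the whole organism for pharmacokinetics, with Mus musculus as the target, at a dose of 10 mg/kg by the oral route (on this read-out lower numbers stand for lower exposure and higher numbers for higher exposure at the dose given), compound 3 (`CC1=C(c2ccccc2)C(c2ccc(OC[C@H](C)N3CC[C@@H](C)C3)cc2)Oc2ccc(O)cc21`) gives 1000 ng.h/mL. For the measured compounds named here, only one other number stands beside it: compound 2 (`CC1=C(c2cccc(O)c2)C(c2ccc(OC[C@H](C)N3CC[C@@H](C)C3)cc2)Oc2ccc(O)cc21`) gives 590 ng.h/mL. The move between them is a 1.7-fold higher number from compound 2 to compound 3 (0.23 log units; within the scatter), so these two values cannot be told apart. Compound 1 (`CC1=C(c2cccc(S(C)(=O)=O)c2)C(c2ccc(OC[C@H](C)N3CC[C@@H](C)C3)cc2)Oc2ccc(O)cc21`) offers no guide, as its entry reads "not determined" (no result reported).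

Compound 4 (`CC1=C(c2ccc(O)cc2)C(c2ccc(OC[C@H](C)N3CC[C@@H](C)C3)cc2)Oc2ccc(O)cc21`) has not yet been measured. It differs from compound 3 by hydroxy in place of hydrogen on an aromatic carbon, the change from phenyl to 4-hydroxyphenyl. Going by the values given here, in compound 4 the new group stands para to a large group, and no measured step covers that place.

Among the compounds with values here, the nearest evidence is the same swap of groups read in reverse, so compound 2, at 590 ng.h/mL, is the only guide. On that basis a small move toward lower exposure is expected, one that stays within the scatter. The expected change is a 1.5-fold lower number from compound 3 to compound 4 (0.19 log units; within the scatter). For compound 4 the estimated value is 650 ng.h/mL, with an expected range from 250 ng.h/mL to 1500 ng.h/mL.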

Compound 4, area under the concentration-time curve: 460 ng.h/mL
Beside the measured number, compound 4's estimate is 1.4-fold (0.15 log units) above it; low and high end bracket the measured number.
By their numbers in this assay, from the lowest: compounds 4, 2 and 3 (each within the scatter of the next, the first and the last beyond it).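

In this assay, adding hydroxy to the phenyl ring to give 4-hydroxyphenyl produces a 2.2-fold lower number from compound 3 to compound 4 (0.34 log units; beyond the scatter), a modest change but the first on this ring to stand clear of the usual scatter. Exchanging 3-hydroxyphenyl for 4-hydroxyphenyl gives a 1.3-fold lower number from compound 2 to compound 4 (0.11 log units; within the scatter), so the two placements of the hydroxy cannot be told apart, and only the 4-hydroxyphenyl compound can be separated from the unsubstituted phenyl compound. Nothing in the available data explains why exposure shifts with this change.

With so few compounds and a step only just past the scatter, the result marks one difference between two compounds and does not establish a rule for this ring. Still open, as far as these compounds go, is how exposure would respond if the hydroxy on the 4-hydroxyphenyl ring gave way to a methoxy group, a fluorine atom or an amine, and whether any of these would stay closer to the unsubstituted phenyl compound than to the two hydroxy compounds.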